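This account rests on a few compounds, and the source may have more. Where it says the series, first, only, none or still open, it means among the compounds named here.

Compound 1 `COc1cccc(-c2nc3c(-c4ccc(Cl)cc4)n[nH]c3c(=O)n2NC(=O)c2ccncc2)c1` and compound 2 `COc1cccc(-c2nc3c(-c4ccc(Cl)cc4)n[nH]c3c(=O)n2NC(=O)c2ccccc2)c1` share one core and differ only in the group on the carbonyl carbon. In a functional assay on HT-29 cells (Homo sapiens) for cytotoxicity, read by sulforhodamine B assay, with a stated time of 2 days, tested at 100 uM (a lower number here means less inhibition, a higher number more inhibition at the concentration tested (going by the name of the read-out)), compound 1 gives 46%, while compound 2 gives 87.3%. For the measured compounds named here, the one measured step, a number 41.3 percentage points higher from compound 1 to compound 2 (beyond the scatter), is large and lies well beyond the scatter. Going by the values given here, compound 2 thus stands highest of the two numbers in this assay, with compound 1 as its only neighbour, a value beyond the scatter lower.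

Compound 3 `CCCc1nc2c(-c3ccc(Cl)cc3)n[nH]c2c(=O)n1NC(=O)c1ccccc1` keeps the benzamido group of compound 2 and alters the core instead: propyl in place of 3-methoxyphenyl on an aromatic carbon. Among the compounds with values here, no measured step concerns this position. Within the data shown here, the only step known, a number 41.3 percentage points higher from compound 1 to compound 2 (beyond the scatter), changes the group on the carbonyl carbon and gives no guidance on exchanging 3-methoxyphenyl for propyl. Neither direction nor size of the effect in this assay can be read from the two compounds measured, so the expectation must be wide. Compound 3 is estimated to give 60%, within a range from 25% to 90%. This estimate amounts to an expected step of a number 27.3 percentage points lower from compound 2 to compound 3 (beyond the scatter), with a spread broad enough to allow a result on either side of compound 2.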

Compound 3, a percentage reported as inhibition, at one concentration (the size of the read-out at that concentration, not a potency): 91.1%
For compound 3 the middle estimate is 31.1 percentage points below the measured one; the whole stated range lies below it.
By their numbers in this assay, from the lowest: compound 1; then compounds 2 and 3 (each within the scatter of the next).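

At this position, on the aromatic carbon between two ring nitrogen atoms and ortho to a benzamido group, exchanging 3-methoxyphenyl for propyl gives in this assay a number 3.8 percentage points higher from compound 2 to compound 3 (within the scatter). For the compounds shown here, this is the first measured change here, and it shows that, with the benzamido group in place, the read-out at the concentration tested does not depend on the six-membered aromatic ring of carbon only, since a propyl chain of 3 heavy atoms with no ring cannot be told apart from a group of 8 heavy atoms; the change on the carbonyl carbon, by contrast, gave a number 41.3 percentage points higher from compound 1 to compound 2 (beyond the scatter). No measurement available here accounts for this result.

The compounds shown leave open whether propyl would behave the same way in a compound carrying pyridin-4-yl on the carbonyl carbon, where the read-out was much lower. They also leave open how far this position stays insensitive to its group, for example with a longer chain such as hexyl, an amine or a carboxylic acid in place of propyl.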